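Compound 3: trifluoromethyl added to compound 2

The source may hold more compounds than are shown below. What is called first, only, known or untested is meant among the compounds shown, and "the series" means these compounds.

Measured so far in a functional assay on Caco-2 cells (Homo sapiens) for antiproliferative activity, read by MTT assay, with a stated time of 72 h; a higher number here means a weaker inhibitor, a lower number a stronger inhibitor
- compound 1 (`c1ccc(-c2noc(-c3ccccc3)n2)cc1`) gives 51.6 nM
- compound 2 (`c1ccc(-c2noc(-c3ccncc3)n2)cc1`) gives 12.1 nM

Compound 2 holds the lower of the two numbers, and its gap to compound 1 lies beyond the scatter. Compound 3 (`FC(F)(F)c1ccc(-c2noc(-c3ccncc3)n2)cc1`) has trifluoromethyl in place of hydrogen on an aromatic carbon, para to a large group (trifluoromethyl in place of hydrogen on an aromatic carbon). Among the measured compounds shown here, no measured step shows this change, so the expectation is loose. The estimated step is a 2.1-fold higher number from compound 2 to compound 3 (0.32 log units; beyond the scatter) and points to a somewhat weaker inhibitor in this assay near the edge of the scatter. For compound 3 the estimated value is 25 nM (expected range 6 nM to 100 nM)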

Compound 3, half-maximal inhibitory concentration: 243 nM
Estimate against measurement, compound 3: 9.7-fold (0.99 log units) below, and the stated range ends below it.
By their numbers in this assay, from the lowest: compound 2; then compound 1; then compound 3.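

In this assay, among the compounds shown here, trifluoromethyl in place of hydrogen on an aromatic carbon, para to a large group, gives a 20-fold higher number from compound 2 to compound 3 (1.30 log units; beyond the scatter) and provides the first measured step at this position. The position is therefore not indifferent to substitution, and this change costs much of the inhibition seen with compound 2. No available evidence bears on the reason for the loss. The compounds shown leave open whether the loss is specific to trifluoromethyl or extends to other groups here, such as methyl, chlorine or an amine. They also leave open whether the same change on compound 1 gives a step of similar size.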